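From 4-Methoxyphenyl to Furan-3-yl on a Shared Core

The source may hold more compounds than are shown below. What is called first, only, known or untested is meant among the compounds shown, and "the series" means these compounds.

Of the compounds shown here, two sharing one core have been measured so far. In an ADME assay on MT4 cells (Homo sapiens) for cytotoxicity, read by MTT assay, with a stated time of 96 h (a lower number here means that less compound is tolerated, a higher number that more compound is tolerated), compound 1 (`C/C(=N\NC(N)=S)c1ccc2c(c1)nc(-c1ccc(Cl)cc1)n2C1CCCCC1`) gives 17000 nM, and compound 2 (`COc1ccc(-c2nc3cc(/C(C)=N/NC(N)=S)ccc3n2C2CCCCC2)cc1`) gives 39000 nM. Compound 2 therefore holds the higher of the two numbers, and compound 1 is its nearest neighbour.

Compound 3 (`C/C(=N\NC(N)=S)c1ccc2c(c1)nc(-c1ccoc1)n2C1CCCCC1`) carries furan-3-yl in place of 4-methoxyphenyl on an aromatic carbon. Going by the values given here, only one measured step bears on this change, and it does so indirectly. That step, with methoxy in place of chloro on an aromatic carbon, is a 2.3-fold higher number from compound 1 to compound 2 (0.36 log units; beyond the scatter). It is modest, though beyond the scatter. Among the compounds with values here, it kept the aromatic ring, whereas the new change replaces the whole group, and no measured compound shows a furan-3-yl group.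

A step of similar or smaller size is therefore expected in this assay, and the direction is uncertain, with a slightly lower number favoured. The expected change is a 1.3-fold lower number from compound 2 to compound 3 (0.11 log units; within the scatter). Compound 3 is estimated at 30000 nM, with an expected range of 12000 nM to 75000 nM.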

Compound 3, half-maximal cytotoxic concentration: 21000 nM
Compound 3: middle estimate off by 1.4-fold (0.15 log units), on the high side; the range from low to high includes it.
By their numbers in this assay, from the lowest: compounds 1, 3 and 2 (each within the scatter of the next, the first and the last beyond it).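

At the aromatic carbon between two ring nitrogen atoms, next to the ring atom that bears a cyclohexyl group, the whole six-membered aromatic ring can be exchanged for a five-membered one, going from 8 heavy atoms to 5, and this assay barely registers it: a 1.9-fold lower number from compound 2 to compound 3 (0.27 log units; within the scatter). Set against the chlorinated partner, the same exchange gives a 1.2-fold higher number from compound 1 to compound 3 (0.09 log units; within the scatter), so compound 3 lies within the scatter of both compound 1 and compound 2, even though those two lie beyond the scatter of each other, and the earlier substituent step alone could not have shown that the aromatic ring at this position need not be a substituted phenyl. Nothing available accounts for why these numbers fall as they do.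

As far as these compounds go, what remains open is whether the same holds for a group without an aromatic ring at this carbon, such as morpholine or a simple amine, and whether furan-2-yl would read like furan-3-yl. Also open, from the compounds shown here alone, is how much of this picture would survive a shorter alkyl chain in place of the cyclohexyl group.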